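The source may report more compounds than this note shows. Statements on the series, on what has been measured and on what is new or still open speak of the compounds shown alone.

Compound 3, with the structure `CCCCCCCCc1ccc(OCC(=O)Cn2nnc(-c3ccncc3)n2)cc1`, gives the lowest number of the three compounds measured in an assay on microsomes from brain for inhibition of Fatty-acid amide hydrolase 1 (Rattus norvegicus), read by fluorescence and HPLC, with a stated time of 60 min; a higher number here means a weaker inhibitor, a lower number a stronger inhibitor: compound 3 gives 24 nM. Its nearest neighbour is compound 1, `CCCCCCCCc1ccc(OCC(=O)Cn2nnc(-c3cccc(C(=O)OC)c3)n2)cc1`, for which compound 1 gives 34 nM, a gap described by a 1.4-fold lower number from compound 1 to compound 3 (0.15 log units; within the scatter). The furthest is compound 2, `CCCCCCCCc1ccc(OCC(=O)Cn2nnc(-c3ccc(S(=O)(=O)N(C)C)cc3)n2)cc1`, where compound 2 gives 590 nM, and the step of a 25-fold lower number from compound 2 to compound 3 (1.39 log units; beyond the scatter) is a large one. Compound 4, `CCCCCCCCc1ccc(OCC(=O)Cn2nnc(-c3ccccn3)n2)cc1`, has not been measured. It differs from compound 3 in one place: pyridin-2-yl in place of pyridin-4-yl on an aromatic carbon; the two have the same atoms, joined differently.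

Going by the values given here, no measured step bears directly on this change. The steps of a 17-fold higher number from compound 1 to compound 2 (1.24 log units; beyond the scatter) and a 25-fold lower number from compound 2 to compound 3 (1.39 log units; beyond the scatter) concern the exchange of one aryl group for another with different substituents, whereas here the same ring is kept and only its point of attachment changes. The step of a 1.4-fold lower number from compound 1 to compound 3 (0.15 log units; within the scatter) shows that a six-membered ring bearing one hetero atom sits close to a substituted phenyl in this assay. He therefore expects the number for compound 4 to stay within the scatter of compound 3, with a step of a 1.7-fold higher number from compound 3 to compound 4 (0.22 log units; within the scatter), and estimates compound 4 at 40 nM, with a likely range from 12 nM to 130 nM.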

Compound 4, half-maximal inhibitory concentration: 18 nM
Compound 4: middle estimate off by 2.2-fold (0.35 log units), on the high side; the measured number falls inside the stated range.
By their numbers in this assay, from the lowest: compounds 4, 3 and 1 (each within the scatter of the next); then compound 2.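

Moving the ring nitrogen of the pyridine, a change the earlier compounds did not cover, gives a 1.3-fold lower number from compound 3 to compound 4 (0.12 log units; within the scatter) in this assay and so leaves pyridin-2-yl and pyridin-4-yl on this aromatic carbon of the shared core indistinguishable in this measurement. The pyridin-2-yl group also stands level with the 3-(methoxycarbonyl)phenyl group, with a 1.9-fold lower number from compound 1 to compound 4 (0.28 log units; within the scatter) as the step, while a 33-fold lower number from compound 2 to compound 4 (1.52 log units; beyond the scatter) sets it far apart from the 4-(dimethylsulfamoyl)phenyl group, so that of the four groups shown at this position only the last stands apart from the others. Nothing given here explains why the place of the ring nitrogen matters so little at this position.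

Still open, from the compounds shown here alone, is whether a pyridin-3-yl group at the same position would fall with the other pyridines, and whether an amine or a carboxylic acid on the pyridine ring would keep the number in this range. The compounds shown also leave open whether the two pyridines would stay level with one another if the octyl chain on the shared core gave way to a shorter chain.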